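This account rests on a few compounds, and the source may have more. Where it says the series, first, only, none or still open, it means among the compounds named here.

In a functional assay on cells (Cancer cell lines, Homo sapiens) for inhibition, with a stated time of 48 h (a lower number here means a stronger inhibitor of growth, a higher number a weaker inhibitor of growth), compound 1 (`COc1cc2c(/C=C3/C(=O)Nc4ccc(Br)cc43)c(Cl)n(C)c2cc1C`) gives 8910 nM and compound 2 (`CN(C)c1ccc2[nH]c(Cl)c(/C=C3/C(=O)Nc4ccc(Cl)cc43)c2c1`) gives 13500 nM while compound 3 (`COc1cc2c(/C=C3/C(=O)N(C)c4ccccc43)c[nH]c2cc1C`) gives 81300 nM as the highest number of the three. Its distance to both others lies beyond the scatter, so compound 3 is the weakest inhibitor of growth so far. Compound 4 (`COc1cc2c(/C=C3/C(=O)N(C)c4ccc(O)cc43)c[nH]c2cc1C`) departs from compound 3 in one place only, with hydroxy in place of hydrogen on an aromatic carbon. Going by the values given here, no two measured compounds differ in a single place, so no direct precedent exists. A modest move to a lower number in this assay is expected, and a 2.0-fold lower number from compound 3 to compound 4 (0.31 log units; beyond the scatter) is the estimated step. Compound 4 is estimated at 40000 nM (range 12000 nM to 100000 nM).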

Compound 4, concentration for total growth inhibition: 15900 nM
Compound 4: the middle estimate sits 2.5-fold (0.40 log units) above what was measured; the measured number falls inside the stated range.
By their numbers in this assay, from the lowest: compounds 1, 2 and 4 (each within the scatter of the next); then compound 3.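

In this assay, hydroxy in place of hydrogen on this aromatic carbon gives a 5.1-fold lower number from compound 3 to compound 4 (0.71 log units; beyond the scatter). Going by these compounds alone, this is the first step that isolates a single change, and it shows that this position of the shared core is sensitive to substitution, with a free hydroxy giving a stronger inhibitor of growth than hydrogen.

As far as these compounds go, whether an amine or a carboxylic acid on the same carbon would move the number as far remains open, as does whether hydroxy would act alike on the core of compound 1. Nothing available bears on why the number falls with this change.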